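This account rests on a few compounds, and the source may have more. Where it says the series, first, only, none or still open, it means among the compounds named here.

Compounds measured so far:
- compound 1 `Nc1ncnc2c1ncn2[C@H]1C[C@H](CO)CO1`: 7%
- compound 2 `CCNC(=O)[C@@H]1CO[C@@H](n2cnc3c(N)ncnc32)[C@@H]1O`: 10%
- compound 3 `OC[C@]1(O)CO[C@@H](n2cnc3c(NCc4cccc(Cl)c4)ncnc32)[C@@H]1O`: 44%

In an assay on CHO cells for displacement of a labelled ligand from adenosine receptor A3 (Homo sapiens), tested at 10 uM (a higher number here means more inhibition at the concentration tested (going by the name of the read-out), a lower number less inhibition), compound 2 gives 10%, the second highest of the three numbers. Compound 1 lies nearest, with a value within the usual scatter of compound 2; compound 3 lies furthest, with a value beyond the scatter above it. The unmeasured compound 4 `Nc1ncnc2c1ncn2[C@@H]1OC[C@@H](CO)[C@H]1O` differs from compound 2 in one place: hydroxymethyl in place of ethylcarbamoyl on a saturated ring carbon. The change moves the saturated ring substituent towards the pattern seen in compound 1, which carries a hydroxymethyl as well, and compound 1 sits within the scatter of compound 2 in this assay. Among the measured compounds shown here, no step of this kind has been measured, so only a small change, not beyond the scatter, is expected in either direction. Compound 4 is therefore estimated at 9% (range 0% to 25%), an expected step of a number 1 percentage points lower from compound 2 to compound 4 (within the scatter).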

Compound 4, a percentage reported as inhibition, at one concentration (the size of the read-out at that concentration, not a potency): 7%
Compound 4: the middle estimate sits 2 percentage points above what was measured; measured number inside the range.
By their numbers in this assay, from the lowest: compounds 1, 4 and 2 (each within the scatter of the next); then compound 3.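

In this assay, hydroxymethyl in place of ethylcarbamoyl on this saturated ring carbon gives a number 3 percentage points lower from compound 2 to compound 4 (within the scatter) and so does not separate the two groups at this position. Hydroxy in place of hydrogen on a saturated ring carbon gives no change at the digits printed from compound 1 to compound 4 (within the scatter) and likewise leaves no readable effect at that place. Nothing available explains either result.

On these data alone, it remains open whether an amine, a carboxylic acid or a longer chain on this ring carbon would move the number beyond the scatter. Also open, as far as these compounds go, is whether either change would behave the same way on a compound carrying the larger nitrogen substituent of compound 3.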